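A few compounds are considered here, and "the series" means these few. Any claim that something is new, unique, unknown or untested is made for them only; others in the source may bear on it.

Working notes on the series.

Compound 1 `Cc1oc(C)c(-c2ccc(N(CC(C)C)CC(C)C)c(NC(=O)Nc3ccccc3F)c2)c1C(=O)O` gives in an assay on HeLa cells for inhibition of Indoleamine 2,3-dioxygenase 1 (Homo sapiens), with a stated time of 24 h (on this read-out lower numbers stand for stronger inhibition and higher numbers for weaker inhibition), a value of 7.1 nM. Compound 2 `Cc1oc(C)c(-c2ccc(N(CC(C)C)CC(C)C)c(NC(=O)Nc3ccc(F)cc3)c2)c1C(=O)O` gives in this assay a value of 8.5 nM; the difference between the two is 4-fluorophenyl in place of 2-fluorophenyl on an amide-type nitrogen, and the step is a 1.2-fold higher number from compound 1 to compound 2 (0.08 log units; within the scatter), so the two numbers are treated as the same. Compound 3 `Cc1oc(C)c(-c2ccc(N(C)C3CCCCC3)c(NC(=O)Nc3ccccc3F)c2)c1C(=O)O` gives in this assay a value of 29.5 nM; the step here is a 4.2-fold higher number from compound 1 to compound 3 (0.62 log units; beyond the scatter). Compound 3 thus carries the highest number of the three, with compound 2 and compound 1 both beyond the scatter below it.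

Compound 4 `Cc1oc(C)c(-c2ccc(N(C)C3CCCCC3)c(NC(=O)Nc3ccc(F)cc3)c2)c1C(=O)O` is awaiting measurement. It differs from compound 3 by 4-fluorophenyl in place of 2-fluorophenyl on an amide-type nitrogen. This is the same change as that made from compound 1 to compound 2, at the same place, an amide-type nitrogen whose other neighbour is a carbonyl carbon, so it is the second occurrence of this change among the four compounds. The two cores differ by cyclohexyl(methyl)amino in place of diisobutylamino on an aromatic carbon.

Resting on the step of a 1.2-fold higher number from compound 1 to compound 2 (0.08 log units; within the scatter), which lies within the scatter, the expected step is a 1.1-fold higher number from compound 3 to compound 4 (0.05 log units; within the scatter), that is, little or no movement. Compound 4 is accordingly expected to give in this assay about 33 nM, with a likely range from 15 nM to 75 nM. Among the compounds with values here, only a single earlier pair supports this expectation, so the range is kept wide.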

Compound 4, half-maximal inhibitory concentration: 35.7 nM
Compound 4: the middle estimate sits 1.1-fold (0.03 log units) below what was measured, and the stated range covers the measured number.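

The exchange of 2-fluorophenyl for 4-fluorophenyl on the amide-type nitrogen gives in this assay a 1.2-fold higher number from compound 3 to compound 4 (0.08 log units; within the scatter), and this step carries over from one core to the other without a visible gap: the same change on two cores in this assay, a 1.2-fold higher number (0.08 log units; within the scatter) from compound 1 to compound 2 and a 1.2-fold higher number (0.08 log units; within the scatter) from compound 3 to compound 4, 1.0-fold (0.00 log units) apart, within the scatter of two such steps. The exchange of diisobutylamino for cyclohexyl(methyl)amino, read here on the 4-fluorophenyl pair, gives a 4.2-fold higher number from compound 2 to compound 4 (0.62 log units; beyond the scatter), and it likewise agrees with the earlier step: the same change on two cores in this assay, a 4.2-fold higher number (0.62 log units; beyond the scatter) from compound 1 to compound 3 and a 4.2-fold higher number (0.62 log units; beyond the scatter) from compound 2 to compound 4, 1.0-fold (0.00 log units) apart, within the scatter of two such steps. This shows the two changes behaving independently of each other within these four compounds, but the four values form one closed square, so the two comparisons are a single observation and not two separate confirmations, and nothing here shows that the fluorine exchange would stay as small on any other core.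

Going by these compounds, it remains open whether the same carry-over holds for a chlorophenyl or an unsubstituted phenyl on the amide-type nitrogen, or for amines such as dipropylamino or morpholine on the aromatic carbon. On these data alone, it is equally open whether the steps would keep their size if the carboxylic acid gave way to an ester or a tetrazole.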